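This account rests on a few compounds, and the source may have more. Where it says the series, first, only, none or still open, it means among the compounds named here.

The measured compounds in a functional assay on MIA PaCa-2 cells (Homo sapiens) for inhibition, read by MTT assay, with a stated time of 3 days; a lower number here means a stronger inhibitor, a higher number a weaker inhibitor:
compound 1 `CC(C)c1noc(N2CCN(C(=O)[C@@H]3CCCN(S(=O)(=O)c4ccc(S(=O)(=O)C(C)C)cc4)C3)CC2)n1` gives 30 nM;
compound 2 `CCOC(=O)[C@@H]1C[C@H](O)CN(S(=O)(=O)c2ccc(S(=O)(=O)N(CC)CC)cc2)C1` gives 300 nM;
compound 3 `CC(C)c1noc(N2CCN(C(=O)[C@@H]3CCCN(S(=O)(=O)c4ccc(S(=O)(=O)C5CCC5)cc4)C3)CC2)n1` gives 20 nM.

Compound 3 has the lowest number of the three in this assay. Its nearest neighbour is compound 1, whose step to compound 3 lies within the scatter, and its furthest is compound 2, whose gap to compound 3 lies beyond it. Compound 4 `CCNS(=O)(=O)c1ccc(S(=O)(=O)N2CCC[C@@H](C(=O)N3CCN(c4nc(C(C)C)no4)CC3)C2)cc1` differs from compound 3 in one place: ethylamino in place of cyclobutyl on a sulfonyl sulfur. Among the compounds with values here, the only measured step at the same sulfonyl sulfur is a 1.5-fold lower number from compound 1 to compound 3 (0.18 log units; within the scatter), which was within the scatter. Within the data shown here, compound 2 carries a related sulfamoyl group but differs from compound 3 elsewhere as well, so it offers no isolated step. Compound 4 is therefore expected to show no step beyond the scatter, a 1.5-fold higher number from compound 3 to compound 4 (0.18 log units; within the scatter). Compound 4 is estimated at 30 nM, with a range from 12 nM to 80 nM.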

Compound 4, half-maximal inhibitory concentration: 200 nM
Compound 4: middle estimate off by 6.7-fold (0.82 log units), on the low side; the whole stated range lies below it.
By their numbers in this assay, from the lowest: compounds 3 and 1 (each within the scatter of the next); then compounds 4 and 2 (each within the scatter of the next).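

In this assay, within the data shown here, the substituent on this sulfonyl sulfur matters more than the earlier compounds showed: cyclobutyl and isopropyl lay within the scatter of each other, whereas ethylamino gave a 10-fold higher number from compound 3 to compound 4 (1.00 log units; beyond the scatter) and also a 6.7-fold higher number from compound 1 to compound 4 (0.82 log units; beyond the scatter). Among these compounds, the change replaces an all-carbon group with one carrying a nitrogen and a hydrogen-bond donor, and it is the first step at this position beyond the scatter. No available evidence accounts for this step. The compounds shown leave open whether the nitrogen, its hydrogen or the loss of the ring goes with the higher number. Dimethylamino or a propyl chain at this position would help separate these.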